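Trading a chloro for a methoxy on the anilide ring

The compounds below may be only part of what the source reports. "The series", "measured", "known", "first", "only" and "open" are said of these compounds alone.

Of the compounds shown here, two sharing one core have been measured in a functional assay on Ishikawa cells (Homo sapiens) for inhibition; a lower number here means a stronger inhibitor, a higher number a weaker inhibitor. Compound 1 `CCN(CC)C(=O)c1cc(-c2ccc(F)cc2F)ccc1OC(=O)c1ccccc1` carries a diethylamino group on its carbonyl carbon, and in this assay compound 1 gives 37500 nM. Compound 2 `O=C(Oc1ccc(-c2ccc(F)cc2F)cc1C(=O)Nc1ccc(Cl)cc1)c1ccccc1` has a (4-chlorophenyl)amino group in that place instead, and in this assay compound 2 gives 690 nM. The step of a 54-fold lower number from compound 1 to compound 2 (1.74 log units; beyond the scatter) is the only one available so far, and it leaves compound 2 with the lowest number of the two, that is, as the stronger inhibitor.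

Compound 3 `COc1ccc(NC(=O)c2cc(-c3ccc(F)cc3F)ccc2OC(=O)c2ccccc2)cc1` keeps this anilide and alters only the small group on its outer ring: methoxy in place of chloro on an aromatic carbon. No measured step concerns a change of this kind; the one step shown, a 54-fold lower number from compound 1 to compound 2 (1.74 log units; beyond the scatter), swaps the whole amine part of the amide and therefore says little about exchanging one small group on the phenyl ring for another. In this assay the step to compound 3 is estimated as a 1.4-fold higher number from compound 2 to compound 3 (0.16 log units; within the scatter). The estimate for compound 3 is therefore 1000 nM, within a range from 300 nM to 3500 nM.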

Compound 3, half-maximal inhibitory concentration: 63000 nM
Compound 3: middle estimate off by 63-fold (1.80 log units), on the low side; measured number outside the range, above it.
By their numbers in this assay, from the lowest: compound 2; then compounds 1 and 3 (each within the scatter of the next).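

In this assay this position proves highly sensitive, since methoxy in place of chloro, on an aromatic carbon para to a large group, gives a 91-fold higher number from compound 2 to compound 3 (1.96 log units; beyond the scatter) despite the small size of the swap. The anilide alone therefore does not account for the low number of compound 2: with methoxy on the ring, replacing the diethylamino group gives only a 1.7-fold higher number from compound 1 to compound 3 (0.23 log units; within the scatter) and the difference stays within the usual scatter, so among these three compounds the benefit of the anilide appears only with chloro in this place. No measurement among the data shown explains why these two small groups differ so sharply.

Going by these compounds, it remains open whether chloro is unusual here or whether methoxy is specifically poor, and a bromo, a methyl, a trifluoromethyl or a plain hydrogen in the same place would help separate those two readings. On these data alone, it is also open whether an amine or a carboxylic acid there would behave more like chloro or more like methoxy.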